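Effect of removing the methoxy group from compound 1

The compounds below may be only part of what the source reports. "The series", "measured", "known", "first", "only" and "open" are said of these compounds alone.

Working notes on the series. Compound 1 `COc1ccc(CNc2nc([SeH])nc3ccccc23)cc1` is tested in a functional assay on CCRF-CEM cells (Homo sapiens) for cytotoxicity, read by MTT assay, with a stated time of 72 h; on this read-out lower numbers stand for higher toxicity in this test and higher numbers for lower toxicity in this test. In this assay compound 1 gives > 100000 nM, which is a limit of the assay and not a number. Compound 2 `COc1ccc(CNc2nc(SC)nc3ccccc23)cc1` is the other measured analogue. In this assay compound 2 gives > 100000 nM, again a limit. The step that the two limits leave unreadable from compound 1 to compound 2 therefore stays unreadable, because both values rest at the limit of > 100000 nM in this assay, at which 2 of the 3 values shown sit. Compound 3 `[SeH]c1nc([SeH])c2cccnc2n1` has "not determined" (no result reported) in this assay. Compound 4 `[SeH]c1nc(NCc2ccccc2)c2ccccc2n1` differs from compound 1 by hydrogen in place of methoxy on an aromatic carbon. Going by the values given here, no measured step bears on this change, and the single measured step gives no size. Compound 4 is expected to stay near the limit, with the step that the limit leaves unreadable from compound 1 to compound 4 estimated as small at most. The estimate for compound 4 is 150000 nM, spanning 30000 nM to 500000 nM.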

Compound 4, concentration lethal to 50% of the cells: > 100000 nM
Compound 4 ended at the assay's limit (the forecaster's own chance of this, stated with the estimate: 75%); the middle value lies beyond the limit too.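

No step can be read between compound 1 and compound 4, because both values are limits of the assay and not numbers: the limit of > 100000 nM in this assay, at which 3 of the 4 values shown sit. The compounds shown leave open which change to the shared core, if any, would give a measurable value.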